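This account rests on a few compounds, and the source may have more. Where it says the series, first, only, none or still open, it means among the compounds named here.

Three compounds have been measured in a functional assay on the whole organism (strain Sprague-Dawley) for inhibition, with Rattus norvegicus as the target, with a stated time of 10 min; on this read-out lower numbers stand for an effect already at smaller amounts and higher numbers for an effect only at larger amounts of compound:

Compound 1, `CCOc1ccc(S(=O)(=O)N(C)C)cc1-c1ncc(C(=O)O)c(=O)[nH]1`: > 50 mg/kg. This value is a limit of the assay, not a number.
Compound 2, `CCOc1ccc(S(=O)(=O)N(CC)CC)cc1-c1ncc(C(=O)O)c(=O)[nH]1`: 40 mg/kg.
Compound 3, `CCOC(=O)c1cnc(-c2cc(S(=O)(=O)N(C)C)ccc2OCC)[nH]c1=O`: 50 mg/kg.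

All three share one core. Compound 2 differs from compound 1 by diethylamino in place of dimethylamino on a sulfonyl sulfur, a change that gave an at least 1.2-fold lower number from compound 1 to compound 2 (0.09 log units; that floor lies within the scatter). Compound 3 differs from compound 1 by ethyl in place of hydrogen on an oxygen next to a carbonyl group, which gave a number no higher from compound 1 to compound 3 (the limit leaves the size open). On these data alone, because compound 1 sits at the limit of > 50 mg/kg in this assay, at which 1 of the 3 values shown sits, the true size of both of these steps stays open.

Compound 4, `CCOC(=O)c1cnc(-c2cc(S(=O)(=O)N(CC)CC)ccc2OCC)[nH]c1=O`, has not yet been measured. Among the compounds with values here, it differs from compound 3 by diethylamino in place of dimethylamino on a sulfonyl sulfur, the same change at the same place as the one from compound 1 to compound 2. Compound 2 at 40 mg/kg and compound 3 at 50 mg/kg lie within the usual scatter of one another, so a small step is expected, a 1.3-fold lower number from compound 3 to compound 4 (0.10 log units; within the scatter), resting on the earlier at least 1.2-fold lower number from compound 1 to compound 2 (0.09 log units; that floor lies within the scatter). Compound 4 is therefore estimated at 40 mg/kg in this assay, most likely between 20 mg/kg and 80 mg/kg.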

Compound 4, dose for 50% inhibition: 10 mg/kg
Estimate against measurement, compound 4: 4.0-fold (0.60 log units) above; the measured number lies below the stated range.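

In this assay, diethylamino in place of dimethylamino on a sulfonyl sulfur gives a 5.0-fold lower number from compound 3 to compound 4 (0.70 log units; beyond the scatter), and ethyl in place of hydrogen on an oxygen next to a carbonyl group gives a 4.0-fold lower number from compound 2 to compound 4 (0.60 log units; beyond the scatter). Each change therefore has a clear effect when compound 4 is the end point, but this does not show that the sulfonyl change has the same size on both cores: the same change on two cores in this assay, an at least 1.2-fold lower number (0.09 log units; that floor lies within the scatter) from compound 1 to compound 2 and a 5.0-fold lower number (0.70 log units; beyond the scatter) from compound 3 to compound 4; the limit leaves it open whether they differ. The change on the oxygen is equally unsettled, so neither step can yet be called transferable from one core to the other: the same change on two cores in this assay, a number no higher (the limit leaves the size open) from compound 1 to compound 3 and a 4.0-fold lower number (0.60 log units; beyond the scatter) from compound 2 to compound 4; the limit leaves it open whether they differ.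

On these data alone, it remains open whether a longer chain on the sulfonyl nitrogen, such as dipropylamino, would give a still lower number than diethylamino, or whether the trend stops at the ethyl groups. As far as these compounds go, it is also open how a propyl group on the oxygen next to the carbonyl group, or an amide in place of the ester, would compare with the ethyl ester of compound 4.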